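Adding one methoxy group to compound 2

This account rests on a few compounds, and the source may have more. Where it says the series, first, only, none or still open, it means among the compounds named here.

Three compounds share a core and differ on one aromatic ring: compound 1 `COc1cccc(/C=C2\CCC/C(=C\c3ccc(OC)c(OC)c3)C2=O)c1`, compound 2 `COc1ccc(/C=C2\CCC/C(=C\c3ccc(OC)c(OC)c3)C2=O)cc1` and compound 3 `COc1ccc(/C=C2\CCC/C(=C\c3ccc(Cl)c(Cl)c3)C2=O)cc1OC`. In an ADME assay on NHDF cells (Homo sapiens) for cytotoxicity, read by MTT assay, with a stated time of 72 h (on this read-out higher numbers stand for weaker inhibition and lower numbers for stronger inhibition), compound 1 gives 11600 nM, compound 2 gives 30900 nM and compound 3 gives 10100 nM. Compound 2 thus has the highest number of the three, which makes it the weakest inhibitor of this small set.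

Compound 4 `COc1ccc(/C=C2\CCC/C(=C\c3ccc(OC)c(OC)c3)C2=O)cc1OC` is compound 2 with a single change on that ring: methoxy in place of hydrogen on an aromatic carbon. Its ring carries the methoxy groups of both compound 1 and compound 2. Within the data shown here, no measured step adds a group to this ring in the same way, so the evidence is indirect.

Among the measured compounds shown here, two steps bear most directly on the question. The step of a 2.7-fold higher number from compound 1 to compound 2 (0.43 log units; beyond the scatter) shows that the number responds to how methoxy is arranged on this ring, and the step of a 3.1-fold lower number from compound 2 to compound 3 (0.49 log units; beyond the scatter) shows that changing this ring in compound 2 can lower the number. The step of a 1.1-fold lower number from compound 1 to compound 3 (0.06 log units; within the scatter) stays within the scatter, so those two compounds sit level.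

A modest move towards them is expected in this assay, an estimated 2.1-fold lower number from compound 2 to compound 4 (0.31 log units; beyond the scatter). For compound 4 the estimated value is 15000 nM, with an expected range from 6000 nM to 38000 nM.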

Compound 4, half-maximal inhibitory concentration: 9700 nM
Beside the measured number, compound 4's estimate is 1.5-fold (0.19 log units) above it, and the stated range covers the measured number.
By their numbers in this assay, from the lowest: compounds 4, 3 and 1 (each within the scatter of the next); then compound 2.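

In this assay, placing a methoxy group ortho to a methoxy group and meta to a large group gives a 3.2-fold lower number from compound 2 to compound 4 (0.50 log units; beyond the scatter), so this position on the ring of compound 2 does respond to a small added group. Among these compounds, the earlier compounds showed only that moving or replacing groups on this ring could alter the number, whereas this step shows that simply adding one can do so. The same compound 4 can also be reached by adding a methoxy group to compound 1, and that gives a 1.2-fold lower number from compound 1 to compound 4 (0.08 log units; within the scatter), so the same kind of change counts in compound 2 but leaves compound 1 and compound 4 level. Nothing measured here explains why the two additions differ.

The compounds shown leave open whether a hydroxy group, a fluorine atom or a longer chain such as ethoxy at this position would lower the number as methoxy does in compound 2. They also leave open whether a methoxy group added to the other aromatic ring would have a similar effect.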